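Replacing the benzyl arm of compound 2 by an arylamino group

The source may hold more compounds than are shown below. What is called first, only, known or untested is meant among the compounds shown, and "the series" means these compounds.

For the measured compounds named here, compound 2 `Cc1ccc(S(=O)(=O)N(Cc2nnc(Cc3cccc(F)c3)o2)c2cccc(Cl)c2C)cc1` stands highest of the three numbers so far in an assay on CHO cells for displacement of a labelled ligand from prostaglandin E2 receptor EP1 subtype (Homo sapiens); on this read-out higher numbers stand for weaker inhibition and lower numbers for stronger inhibition: compound 2 gives 316 nM, compound 1 `Cc1ccc(S(=O)(=O)N(Cc2nnc(Cc3ccc(F)cc3)o2)c2cccc(Cl)c2C)cc1` gives 200 nM, and compound 3 `COc1ccc(Cc2nnc(CN(c3cccc(Cl)c3Cl)S(=O)(=O)c3ccc(Cl)cc3)o2)cc1` gives 20 nM. Going by the values given here, the only single-place step measured, a 1.6-fold higher number from compound 1 to compound 2 (0.20 log units; within the scatter), concerns the fluorine position on the benzyl arm and is within the scatter. Compound 3 differs from compound 2 in several places at once, so its lower number cannot be assigned to any one change.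

Compound 4 `COc1ccc(Nc2nnc(CN(c3cccc(Cl)c3C)S(=O)(=O)c3ccc(C)cc3)o2)cc1` is derived from compound 2 by (4-methoxyphenyl)amino in place of 3-fluorobenzyl on an aromatic carbon. Among the compounds with values here, no measured step touches the group bound to this carbon of the five-membered aromatic ring with 2 nitrogen and 1 oxygen, so the series gives no direct guide. Without any pairing that bears on it, no step beyond the scatter is expected in this assay, and the estimate for compound 4 is 250 nM, expected within 60 nM to 1000 nM, meaning an expected step of a 1.3-fold lower number from compound 2 to compound 4 (0.10 log units; within the scatter).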

Compound 4, half-maximal inhibitory concentration: 31.6 nM
Beside the measured number, compound 4's estimate is 7.9-fold (0.90 log units) above it; the whole stated range lies above it.
By their numbers in this assay, from the lowest: compounds 3 and 4 (each within the scatter of the next); then compounds 1 and 2 (each within the scatter of the next).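

In this assay the group on this aromatic carbon of the five-membered ring carries weight: the change to (4-methoxyphenyl)amino holds against both fluorobenzyl partners (a 10-fold lower number from compound 2 to compound 4 (1.00 log units; beyond the scatter) and a 6.3-fold lower number from compound 1 to compound 4 (0.80 log units; beyond the scatter)). For the compounds shown here, the earlier single-place step, moving the fluorine on the benzyl arm, stayed within the scatter, so these are the first single-place steps beyond it. No available evidence bears on why the number falls at this position.

The change swaps the chain carbon for an amino link and the fluorine for a methoxy group at once, so the compounds shown do not tell which part accounts for the step. Open, from the compounds shown here alone, are a phenylamino group without the methoxy, a methyl on the amino nitrogen, and a longer chain between the amino link and the phenyl ring.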